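Notes on the ring-amine chain: from compound 2 to compound 4

The compounds below may be only part of what the source reports. "The series", "measured", "known", "first", "only" and "open" are said of these compounds alone.

Measured compounds:
Compound 1 `O=C(NO)c1cccc(-c2cn([C@@H]3C[C@@H](CO)N(CCCc4ccccc4)C3)nn2)c1` gives < 10% in an assay on Sf9 cells for inhibition of histone deacetylase 11 (Homo sapiens), read by fluorescence, tested at 0.5 uM (on this read-out lower numbers stand for less inhibition and higher numbers for more inhibition at the one concentration tested (going by the name of the read-out)), a limit of the assay.
Compound 2 `O=C(NO)c1cccc(-c2cn([C@H]3C[C@H](CO)N(Cc4ccccc4)C3)nn2)c1` gives < 10% in this assay, also a limit.
Compound 3 `O=C(NO)c1cccc(-c2cn([C@H]3C[C@@H](CO)N(Cc4ccccc4)C3)nn2)c1` gives < 10% in this assay, again a limit.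

Compound 2 therefore stands only at a limit, with no number of its own; every value shown sits at that same limit (the limit of < 10% in this assay, at which 3 of the 3 values shown sit). Within the data shown here, the one measured step, a step that the two limits leave unreadable from compound 2 to compound 3, has no readable size; both of its ends are limits, and the two compounds differ only in configuration as drawn (the fact that compounds 2 and 3 differ only in the configuration as drawn).

Compound 4 `O=C(NO)c1cccc(-c2cn([C@H]3C[C@H](CO)N(CCCc4ccccc4)C3)nn2)c1` differs from compound 2 by phenethyl in place of phenyl on a saturated chain carbon bound to an amine nitrogen in a ring. Compound 1 already carries the 3-phenylpropyl chain on the ring amine and gives < 10%, a limit. Among the measured compounds shown here, no measured step offers a readable size, so no direction beyond the scatter can be expected for the change to compound 4. Compound 4 is expected to sit at 5%, in a range from 0% to 15%, most probably reported once more as a limit. The step that the limit leaves unreadable from compound 2 to compound 4 is accordingly estimated to be nil within the scatter.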

Compound 4, a percentage reported as inhibition, at one concentration (the size of the read-out at that concentration, not a potency): < 10%
Compound 4 was reported as a limit; the forecaster's own chance of this, stated with the estimate: 85%; the middle value lies beyond the limit too.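

Compound 4 gives < 10% in this assay, a limit. Among these compounds, no step from compound 2 or compound 1 to compound 4 can be read. The compounds shown leave open whether the chain on the ring amine or the configuration as drawn has any bearing on inhibition: the limit of < 10% in this assay, at which 4 of the 4 values shown sit.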